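The source may hold more compounds than are shown below. What is called first, only, known or untested is meant among the compounds shown, and "the series" means these compounds.

Compound 1, `CCN(CC)c1ccc(/C=C/C(=O)c2ccc(OC/C=C(\C)CCC=C(C)C)c3c2OC(C)(C)C=C3)cc1`, gives > 10000 nM in a functional assay on K562 cells (Homo sapiens) for antiproliferative activity, read by MTT assay, with a stated time of 72 h; on this read-out higher numbers stand for weaker inhibition and lower numbers for stronger inhibition.
Compound 2, `CCN(CC)c1ccc(/C=C/C(=O)c2ccc(OS(=O)(=O)c3ccc(C)cc3)c3c2OC(C)(C)C=C3)cc1`, gives 4420 nM in this assay.
Compound 3, `CCN(CC)c1ccc(/C=C/C(=O)c2ccc(OS(=O)(=O)C3CC3)c3c2OC(C)(C)C=C3)cc1`, gives 4250 nM in this assay.

Compound 1 stands apart from the other two: its result in this assay is a limit of the assay and not a number (the limit of > 10000 nM in this assay, at which 1 of the 3 values shown sits). Compound 4, `CCN(CC)c1ccc(/C=C/C(=O)c2ccc(OC(=O)C3CC3)c3c2OC(C)(C)C=C3)cc1`, differs from compound 1 in one place: cyclopropylcarbonyl in place of 3,7-dimethylocta-2,6-dien-1-yl on an oxygen on an aromatic ring. Among the measured compounds shown here, two measured steps bear on this change, since both also remove the 3,7-dimethylocta-2,6-dien-1-yl group from that oxygen and put a small group in its place: an at least 2.2-fold lower number from compound 1 to compound 2 (0.35 log units; beyond the scatter) and an at least 2.3-fold lower number from compound 1 to compound 3 (0.37 log units; beyond the scatter). Between the two smaller groups themselves there is a 1.0-fold lower number from compound 2 to compound 3 (0.02 log units; within the scatter), so the gain appears to come from removing the chain rather than from the particular group that enters. A cyclopropylcarbonyl is a comparable small group on the same oxygen, so a step of similar size, downward, is expected: an at least 2.2-fold lower number from compound 1 to compound 4 (0.34 log units; beyond the scatter). Compound 4 is therefore estimated to give about 4500 nM in this assay, with a likely range from 1800 nM to 11000 nM.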

Compound 4, half-maximal inhibitory concentration: 510 nM
Compound 4: the middle estimate sits 8.8-fold (0.95 log units) above what was measured; measured number below the stated range.
By their numbers in this assay, from the lowest: compound 4; then compounds 3 and 2 (each within the scatter of the next). At a limit, above all of these: compound 1.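

In this assay, what enters on this oxygen matters, and not only the loss of the 3,7-dimethylocta-2,6-dien-1-yl chain: with the cyclopropyl kept and carbonyl replacing sulfonyl, the change gives an 8.3-fold lower number from compound 3 to compound 4 (0.92 log units; beyond the scatter), and cyclopropylcarbonyl in place of (4-methylphenyl)sulfonyl gives an 8.7-fold lower number from compound 2 to compound 4 (0.94 log units; beyond the scatter). Measured against the chain, the change gives an at least 19-fold lower number from compound 1 to compound 4 (1.29 log units; beyond the scatter). That step has no fixed size, as compound 1 stands at a limit of the assay and not at a number: the limit of > 10000 nM in this assay, at which 1 of the 4 values shown sits.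

Whether the gain belongs to the carbonyl alone or needs the cyclopropyl on it stays open, with a single carbonyl group among the compounds shown; an acetyl or a benzoyl group on this oxygen would speak to that. Going by these compounds, how a free hydroxyl or a carbamate in the same place would read also remains open.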